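A fluoro step on the benzyl group of compound 2

A few compounds are considered here, and "the series" means these few. Any claim that something is new, unique, unknown or untested is made for them only; others in the source may bear on it.

The values measured in a functional assay on GBM3 cells (Homo sapiens) for antiproliferative activity, read by WST assay, with a stated time of 72 h (on this read-out lower numbers stand for stronger inhibition and higher numbers for weaker inhibition), are these:

compound 1 (`O=C(Nc1cccc(Cl)c1)Nc1cc2ncncc2cc1OCc1ccccc1Cl`) gives 2800 nM
compound 2 (`O=C(Nc1ccccc1F)Nc1cc2ncncc2cc1OCc1ccccc1`) gives 5900 nM
compound 3 (`O=C(Nc1ccc(C(F)(F)F)cc1)Nc1cc2ncncc2cc1OCc1ccccc1`) gives 3700 nM

Compound 2 sits at the high end of these numbers, and compound 3 cannot be separated from it. The single-place step between them is a 1.6-fold lower number from compound 2 to compound 3 (0.20 log units; within the scatter) and it changes the aryl group on an amide-type nitrogen. Compound 1 reads lower than compound 2 beyond the scatter, but the two differ in more than one place.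

Compound 4 (`O=C(Nc1ccccc1F)Nc1cc2ncncc2cc1OCc1cccc(F)c1`) is compound 2 with fluoro in place of hydrogen on an aromatic carbon in the benzyl group: fluoro in place of hydrogen on an aromatic carbon, turning benzyl into 3-fluorobenzyl. Among the compounds with values here, no measured step isolates a change to that group, so the data give only weak guidance. In this assay the expected change is a 1.3-fold lower number from compound 2 to compound 4 (0.12 log units; within the scatter) and nothing beyond the scatter is anticipated. Compound 4 is estimated at 4500 nM (expected range 2200 nM to 9000 nM).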

Compound 4, half-maximal inhibitory concentration: 8100 nM
For compound 4 the middle estimate is 1.8-fold (0.26 log units) below the measured one, within the range that was stated.
By their numbers in this assay, from the lowest: compounds 1, 3, 2 and 4 (each within the scatter of the next, the first and the last beyond it).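

In this assay, within the data shown here, the step from benzyl to 3-fluorobenzyl gives a 1.4-fold higher number from compound 2 to compound 4 (0.14 log units; within the scatter), the first single-place reading on the benzyl group, with the aryl group on the amide-type nitrogen held fixed. A single fluoro at this place therefore gives no change that can be separated from the usual scatter, and the direction of the step cannot be read. No measurement shown here offers an explanation for this result.

Chloro on the benzyl group appears in compound 1, but that compound differs from compound 2 in more than one place, so the effect of that chloro cannot be isolated. From the compounds shown here alone, whether an amine, a carboxylic acid or a longer chain in place of this fluoro would move the number beyond the scatter remains open.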